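Swapping the amide aryl group in weak phosphatase inhibitors

The compounds below may be only part of what the source reports. "The series", "measured", "known", "first", "only" and "open" are said of these compounds alone.

Compound 1: `O=C(COc1ccc2cc(C(O)(C(F)(F)F)C(F)(F)F)c(O)cc2c1)Nc1nc2ccccc2s1`, 10900 nM in an assay on isolated protein for inhibition of receptor-type tyrosine-protein phosphatase C (Homo sapiens), read by spectrophotometry; on this read-out higher numbers stand for weaker inhibition and lower numbers for stronger inhibition
Compound 2: `COc1ccc(CNC(=O)COc2ccc3cc(C(O)(C(F)(F)F)C(F)(F)F)c(O)cc3c2)cc1OC`, > 20000 nM in this assay
Compound 3: `O=C(COc1ccc2cc(C(O)(C(F)(F)F)C(F)(F)F)c(O)cc2c1)Nc1cccc2ccccc12`, 29100 nM in this assay

All three compounds share one core and differ only in the group carried on the amide-type nitrogen. Compound 3, with naphthalen-1-yl there, gives the highest of the two numbers; compound 1 sits nearest, and the step of a 2.7-fold higher number from compound 1 to compound 3 (0.43 log units; beyond the scatter) is modest but beyond the scatter. For compound 2 the value is a limit of the assay and not a number (the limit of > 20000 nM in this assay, at which 1 of the 3 values shown sits), so the step of an at least 1.8-fold higher number from compound 1 to compound 2 (0.26 log units; that floor lies within the scatter) has only a floor, and the step that the limit leaves unreadable from compound 2 to compound 3 cannot be read at all.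

Compound 4, `CC(C)c1ccc(NC(=O)COc2ccc3cc(C(O)(C(F)(F)F)C(F)(F)F)c(O)cc3c2)cc1`, has not yet been measured. It differs from compound 3 in one place: 4-isopropylphenyl in place of naphthalen-1-yl on an amide-type nitrogen. The measured steps show that changing this group moves the number only modestly, and every group tried so far leaves inhibition weak. A step of about a 1.2-fold lower number from compound 3 to compound 4 (0.07 log units; within the scatter) is therefore expected, which is within the scatter. Compound 4 is estimated at 25000 nM in this assay, with a range from 10000 nM to 60000 nM.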

Compound 4, half-maximal inhibitory concentration: 7800 nM
Compound 4: the middle estimate sits 3.2-fold (0.51 log units) above what was measured; the whole stated range lies above it.
By their numbers in this assay, from the lowest: compounds 4 and 1 (each within the scatter of the next); then compound 3.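

Putting 4-isopropylphenyl in place of naphthalen-1-yl gives a 3.7-fold lower number from compound 3 to compound 4 (0.57 log units; beyond the scatter), so in this assay this position does not need two aromatic rings, and the choice of group can matter more than the first steps suggested. The step of an at least 2.5-fold lower number from compound 2 to compound 4 (0.40 log units; beyond the scatter) gives only a floor, while a 1.4-fold lower number from compound 1 to compound 4 (0.15 log units; within the scatter) shows that 4-isopropylphenyl and 1,3-benzothiazol-2-yl cannot be told apart here. Compound 2 carries a limit of the assay and not a number: the limit of > 20000 nM in this assay, at which 1 of the 4 values shown sits.

As far as these compounds go, whether an amine or a carboxylic acid in place of the isopropyl group, or a longer carbon chain there, would lower the number further stays open. Also open, from the compounds shown here alone, is how plain phenyl, without the isopropyl group, would compare on the amide-type nitrogen.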